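Working notes: aryl fluorination on the cyclopropane of compound 3

The source may hold more compounds than are shown below. What is called first, only, known or untested is meant among the compounds shown, and "the series" means these compounds.

The series shares a core in which a cyclopropanecarboxamide carries a biphenyl-bearing nitrogen and a short amine chain. Compound 1 `CN[C@@H](CC(C)C)CN(C(=O)[C@@H]1C[C@H]1c1ccccc1)c1ccc(-c2ccccc2)cc1` gives 2 nM in a functional assay for agonist activity at G protein-coupled receptor 88 (Homo sapiens), read by HTRF and cAMP accumulation (on this read-out higher numbers stand for an effect only at larger amounts of compound and lower numbers for an effect already at smaller amounts), and compound 2 `CC(C)CCNCCN(C(=O)[C@@H]1C[C@H]1c1ccccc1)c1ccc(-c2ccccc2)cc1` gives 5.1 nM. Compound 3 `CC[C@H](C)[C@H](N)CN(C(=O)[C@@H]1C[C@H]1c1ccc(F)cc1)c1ccc(-c2ccccc2)cc1` gives 600 nM, the highest number of the three, with compound 2 as the nearest and compound 1 as the furthest. Going by the values given here, the only step measured so far is within the amine chain, a 2.6-fold higher number from compound 1 to compound 2 (0.41 log units; beyond the scatter), and does not touch the aryl ring on the cyclopropane.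

Compound 4 `CC[C@H](C)[C@H](N)CN(C(=O)[C@@H]1C[C@H]1c1cc(F)cc(F)c1)c1ccc(-c2ccccc2)cc1` changes that ring: 3,5-difluorophenyl in place of 4-fluorophenyl on a saturated ring carbon. Among the compounds with values here, no measured pair shows this change, so nothing bears directly on it, and the step from the amine chain is of no help in direction. The expectation is therefore a step of a 1.1-fold lower number from compound 3 to compound 4 (0.04 log units; within the scatter), that is, none beyond the scatter. Compound 4 is estimated at 550 nM in this assay, within a range from 150 nM to 2000 nM.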

Compound 4, half-maximal effective concentration: 960 nM
Beside the measured number, compound 4's estimate is 1.7-fold (0.24 log units) below it, within the range that was stated.
By their numbers in this assay, from the lowest: compound 1; then compound 2; then compounds 3 and 4 (each within the scatter of the next).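

Going by these compounds alone, the only measured change on the aryl ring at the cyclopropane gives a 1.6-fold higher number from compound 3 to compound 4 (0.20 log units; within the scatter) in this assay. On this read-out, 3,5-difluorophenyl in place of 4-fluorophenyl on a saturated ring carbon therefore produces no step beyond the scatter, which the earlier step in the amine chain could not show. No supporting data accompany this result, so the absence of a step cannot be explained from what is available.

Compound 3 and compound 4 differ from compound 1 and compound 2 in both the amine chain and the aryl ring, so the large gap between these pairs cannot be assigned to either place. As far as these compounds go, it also remains open whether a methoxy group or a nitrile on this ring, rather than fluorine, would move the number beyond the scatter.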